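This account rests on a few compounds, and the source may have more. Where it says the series, first, only, none or still open, it means among the compounds named here.

Going by the values given here, in a functional assay on DU-145 cells (Homo sapiens) for antiproliferative activity, read by sulforhodamine B assay, with a stated time of 3 days (on this read-out lower numbers stand for stronger inhibition of growth and higher numbers for weaker inhibition of growth), compound 2 `O=C(Nc1cccc(Nc2ncc(F)c(Nc3ccc(F)cc3)n2)c1)c1cnccn1` gives 26400 nM, the highest of the numbers measured so far. Compound 3 `O=C(Nc1cccc(Nc2ncc(F)c(Nc3ccc(F)cc3)n2)c1)c1cccc([N+](=O)[O-])c1` gives 12600 nM. Compound 1 `O=C(Nc1ccc(C(F)(F)F)cc1)c1cccc(Nc2ncc(F)c(Nc3ccc(F)cc3)n2)c1` gives > 10000 nM, which is a limit of the assay and not a number. Compound 4 `O=C(Nc1cc(Cl)cc(Cl)c1)c1cccc(Nc2ncc(F)c(Nc3ccc(F)cc3)n2)c1` differs from compound 2 by having (3,5-dichlorophenyl)carbamoyl in place of ((pyrazin-2-yl)carbonyl)amino on an aromatic carbon. The nearest measured change, 3-nitrophenyl in place of pyrazin-2-yl, gave a 2.1-fold lower number from compound 2 to compound 3 (0.32 log units; beyond the scatter), a modest step. Compound 1 also carries a phenylcarbamoyl group, but its limit gives no exact size. A small expected change, a 1.8-fold lower number from compound 2 to compound 4 (0.25 log units; within the scatter), is therefore estimated, with no step beyond the scatter. For compound 4 the expected value is 15000 nM, within an estimated range of 5000 nM to 40000 nM.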

Compound 4, concentration for 50% growth inhibition: 17500 nM
Beside the measured number, compound 4's estimate is 1.2-fold (0.07 log units) below it; measured number inside the range.
By their numbers in this assay, from the lowest: compounds 3, 4 and 2 (each within the scatter of the next, the first and the last beyond it).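

In this assay, (3,5-dichlorophenyl)carbamoyl in place of ((pyrazin-2-yl)carbonyl)amino gives a 1.5-fold lower number from compound 2 to compound 4 (0.18 log units; within the scatter). At this position, then, turning the amide around and exchanging the two-nitrogen ring for a dichlorinated carbon-only ring, taken together, leaves the number within the scatter. The step from compound 1 to compound 4 cannot be read because compound 1 gives a limit and not a number: the limit of > 10000 nM in this assay, at which 1 of the 4 values shown sits.

From the compounds shown here alone, whether an amine or a carboxylic acid at this position would give a clearly lower number remains open. So does the separate contribution of amide direction and ring.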